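This account rests on a few compounds, and the source may have more. Where it says the series, first, only, none or still open, it means among the compounds named here.

Working notes on the carbonyl substituent of this small set. All three measured compounds share one core and differ only in the group on the carbonyl carbon. In an assay on HEK293 cells for positive allosteric modulation of metabotropic glutamate receptor 5 (Homo sapiens), read by FLIPR (a higher number here means that more compound is needed for the effect, a lower number that less compound is needed), compound 1 `CC1CCCC(C(=O)N2CC(c3nc(-c4cccc(Cl)c4)no3)C2)C1` gives 410 nM. Compound 2 `CC1CCC(C(=O)N2CC(c3nc(-c4cccc(Cl)c4)no3)C2)CC1` gives 1500 nM in this assay, and the step of a 3.7-fold higher number from compound 1 to compound 2 (0.56 log units; beyond the scatter) is modest. Compound 3 `O=C(c1cccc(F)c1)N1CC(c2nc(-c3cccc(Cl)c3)no2)C1` reaches only the limit of this assay, > 10000 nM (the limit of > 10000 nM in this assay, at which 1 of the 3 values shown sits), so it stands at the weak end without a firm number. The steps of an at least 24-fold higher number from compound 1 to compound 3 (1.38 log units; beyond the scatter) and an at least 6.6-fold higher number from compound 2 to compound 3 (0.82 log units; beyond the scatter) both show the aromatic group falling well behind the two non-aromatic rings.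

The next change is 3-methylpyrrolidin-1-yl in place of 3-fluorophenyl on a carbonyl carbon, giving compound 4 `CC1CCN(C(=O)N2CC(c3nc(-c4cccc(Cl)c4)no3)C2)C1`. Compound 4 thus returns to a non-aromatic ring, as in compounds 1 and 2, though a five-membered one with a hetero atom, which neither measured step covers directly. Since the steps of an at least 24-fold higher number from compound 1 to compound 3 (1.38 log units; beyond the scatter) and an at least 6.6-fold higher number from compound 2 to compound 3 (0.82 log units; beyond the scatter) place the two non-aromatic rings well ahead of the aromatic one, a number lower than that of compound 3 is expected for compound 4. The expected step for compound 4 is an at least 11-fold lower number from compound 3 to compound 4 (1.04 log units; beyond the scatter). The estimate for compound 4 in this assay is 900 nM, within 200 nM to 5000 nM.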

Compound 4, half-maximal effective concentration: > 10000 nM
Compound 4: no number, only a limit; the forecaster's own chance of this, stated with the estimate: 15%; middle value at least 11-fold (1.04 log units) from the limit.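

A non-aromatic ring on the carbonyl carbon is not enough for a measurable number in this assay: the change to 3-methylpyrrolidin-1-yl gives an at least 24-fold higher number from compound 1 to compound 4 (1.38 log units; beyond the scatter) and an at least 6.6-fold higher number from compound 2 to compound 4 (0.82 log units; beyond the scatter). The gap between the two methylcyclohexyl groups and 3-fluorophenyl therefore does not extend to a simple split of non-aromatic against aromatic groups, and compound 4 goes against such a split. Compound 4 ends at a limit, as compound 3 does, so the step between them cannot be read and the two groups cannot be ordered: the limit of > 10000 nM in this assay, at which 2 of the 4 values shown sit.

The compounds shown leave open whether the loss follows the smaller ring or the ring nitrogen attached to the carbonyl carbon. A piperidin-1-yl or a cyclopentyl group on the carbonyl carbon would separate these two readings.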